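Branching the Piperazine Chain: Propyl to Isobutyl

A few compounds are considered here, and "the series" means these few. Any claim that something is new, unique, unknown or untested is made for them only; others in the source may bear on it.

Measured so far:
compound 1 `O=S(=O)(c1cccc2ccccc12)c1cccc2oc(N3CCNCC3)nc12` gives 3.1 nM
compound 2 `CCCN1CCN(c2nc3c(S(=O)(=O)c4cccc5ccccc45)cccc3o2)CC1` gives 36 nM

Both numbers come from an assay on HeLa cells for displacement of a labelled ligand from 5-hydroxytryptamine receptor 6 (Homo sapiens); a lower number here means a stronger inhibitor, a higher number a weaker inhibitor. Going by the values given here, compound 2 has the higher of the two numbers; its nearest neighbour is compound 1, and the single measured step, a 12-fold higher number from compound 1 to compound 2 (1.06 log units; beyond the scatter), is large and beyond the scatter. Compound 3 `CC(C)CN1CCN(c2nc3c(S(=O)(=O)c4cccc5ccccc45)cccc3o2)CC1` is the next member. It differs from compound 2 by methyl in place of hydrogen on a saturated chain carbon bound to two saturated chain carbons; cut one bond further out, the change reads propyl to isobutyl on the piperazine nitrogen. Among the compounds with values here, no measured step covers this kind of change; the only step in hand concerns adding the whole propyl chain to the bare amine, not extending it. The expectation is therefore modest: compound 3 is expected to come out near compound 2 or somewhat higher, with an estimated step of a 1.5-fold higher number from compound 2 to compound 3 (0.18 log units; within the scatter) in this assay. Compound 3 is estimated at 55 nM, within a range from 15 nM to 200 nM.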

Compound 3, inhibition constant: 176 nM
Estimate against measurement, compound 3: 3.2-fold (0.51 log units) below, within the range that was stated.
By their numbers in this assay, from the lowest: compound 1; then compound 2; then compound 3.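

In this assay, the single methyl that turns propyl into isobutyl gives a 4.9-fold higher number from compound 2 to compound 3 (0.69 log units; beyond the scatter), so this position on the chain responds to one added carbon, not only to the presence of a chain. Measured from the bare amine, isobutyl gives a 57-fold higher number from compound 1 to compound 3 (1.75 log units; beyond the scatter), a larger rise than a 12-fold higher number from compound 1 to compound 2 (1.06 log units; beyond the scatter) seen with propyl, and across these three compounds the number climbs from hydrogen to propyl to isobutyl. No measurement here accounts for why this branch raises the number.

From the compounds shown here alone, what remains open is whether the branch itself matters or simply the larger chain, and a straight butyl chain on the piperazine nitrogen would separate those two readings. A methyl or ethyl group there would show how small a chain can be while the number still rises above that of compound 1.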